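The source may report more compounds than this note shows. Statements on the series, on what has been measured and on what is new or still open speak of the compounds shown alone.

In a functional assay on MIA PaCa-2 cells (Homo sapiens) for inhibition, read by MTT assay, with a stated time of 48 h, tested at 10 uM (a lower number here means less inhibition of growth, a higher number more inhibition of growth at the concentration tested), two compounds have been measured so far. Compound 1, `Cc1cc(=O)c2c(O)cc(OCc3ccco3)c([C@H]3CCN(C)C[C@H]3O)c2o1`, gives 7%, and compound 2, `Cc1oc2c([C@H]3CCN(C)C[C@H]3O)c(O)cc(O)c2c(=O)c1C(O)c1ccc([N+](=O)[O-])cc1`, gives 2%. These two values lie within the usual scatter of each other, so compound 2 stands level with compound 1, and both show little inhibition of growth at the concentration tested.

Compound 3, `Cc1oc2c([C@H]3CCN(C)C[C@H]3O)c(O)cc(O)c2c(=O)c1C(O)c1c(Cl)cccc1Cl`, has yet to be measured. It keeps compound 2 except for one group: 2,6-dichlorophenyl in place of 4-nitrophenyl on a saturated chain carbon bound to an aromatic carbon and an oxygen on a saturated carbon. Thus, 2,6-dichlorophenyl stands in place of 4-nitrophenyl on a saturated chain carbon bound to an aromatic carbon and an oxygen on a saturated carbon.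

For the measured compounds named here, no two measured compounds differ in only one place, so the data offer no direct precedent for this exchange. A small rise in this assay is expected, most likely not beyond the scatter. The expected range reaches further upward because compound 2 gives 2% and has little room to fall. The estimated step is a number 6 percentage points higher from compound 2 to compound 3 (within the scatter). For compound 3 the expected value is 8%, with an estimated range of 0% to 30%.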

Compound 3, percent growth inhibition at one concentration: 0%
Compound 3: the middle estimate sits 8 percentage points above what was measured, and the stated range covers the measured number.
By their numbers in this assay, from the lowest: compounds 3, 2 and 1 (each within the scatter of the next).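

For the compounds shown here, replacing 4-nitrophenyl with 2,6-dichlorophenyl on a saturated chain carbon bound to an aromatic carbon and an oxygen on a saturated carbon gives a number 2 percentage points lower from compound 2 to compound 3 (within the scatter) in this assay and provides the first direct comparison at this position. The two compounds stand level, so at this position a group with 2 hydrogen-bond acceptors and one with none read alike, although both readings lie so low that the result says little about how far this place can be varied. The data contain no measurement that accounts for this outcome.

The compounds shown leave open whether any aromatic group on this carbon matters for growth inhibition in this assay or whether the shared core alone sets the low readings, and compound 1 differs from the others in more than one place and so cannot settle this. Also open, on these data alone, is whether a different group here, such as a primary amine, a carboxylic acid or a longer alkyl chain in place of the ring, would lift the reading beyond the scatter.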